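Working notes: from compound 2 to compound 4

The source may report more compounds than this note shows. Statements on the series, on what has been measured and on what is new or still open speak of the compounds shown alone.

Measured in an ADME assay on MDCK cells (Canis lupus familiaris) for cytotoxicity (on this read-out higher numbers stand for lower toxicity in this test and lower numbers for higher toxicity in this test), with every value a limit of the assay:
- compound 1 `CC(=O)Nc1ccc2oc(-c3ccnc(C(=O)N4CC5CC4CN5C(c4ccccc4)c4nnn(C)n4)c3)nc2c1` | > 50000 nM
- compound 2 `CC(=O)Nc1ccc2oc(-c3ccnc(C(=O)N4CCN(C(c5nnn(C)n5)c5ccccc5F)CC4)c3)nc2c1` | > 50000 nM
- compound 3 `CC(=O)Nc1ccc2oc(-c3ccnc(C(=O)N4CCN([C@@H](c5ccc(F)cc5)c5nnn(C)n5)CC4)c3)nc2c1` | > 200000 nM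

Not yet measured:
- compound 4 `CC(=O)Nc1ccc2oc(-c3ccnc(C(=O)N4CCN(C(c5ccc(OC(F)(F)F)cc5)c5nnn(C)n5)CC4)c3)nc2c1`

Compound 2 stands at the limit of > 50000 nM in this assay, at which 2 of the 3 values shown sit, so it is known only as a limit. Compound 4 differs from compound 2 by 4-(trifluoromethoxy)phenyl in place of 2-fluorophenyl on a saturated chain carbon bound to an amine nitrogen in a ring and an aromatic carbon. For the measured compounds named here, no step between measured compounds is available in this assay to guide the estimate. The estimated step that the limit leaves unreadable from compound 2 to compound 4 is expected to stay within the scatter, with no direction favoured. This expectation rests on compound 2 and its limit of > 50000 nM as the closest reference. Compound 4 is expected near 60000 nM, with an estimated range of 25000 nM to 200000 nM, and may be reported only as a limit.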

Compound 4, half-maximal cytotoxic concentration: > 50000 nM
Compound 4: only a limit was reported (the forecaster's own chance of this, stated with the estimate: 75%); the middle value is on the limit's open side.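

No step can be read from compound 2 to compound 4 in this assay, since both results are limits of the assay. The compounds shown leave open whether 4-(trifluoromethoxy)phenyl in place of 2-fluorophenyl changes this read-out at all.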